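Chloro in Place of Fluoro: Compound 2 to Compound 3

The compounds below may be only part of what the source reports. "The series", "measured", "known", "first", "only" and "open" are said of these compounds alone.

Of the compounds shown here, two sharing one core have been measured so far. Compound 1 `COc1ccc(S(=O)(=O)c2cnc3ccc(Cl)cc3c2N2CCC(C)CC2)cc1Cl` carries a chloro on its fused ring system together with a substituted arylsulfonyl group. In an assay on isolated protein for displacement of a labelled ligand from metabotropic glutamate receptor 5 (Homo sapiens), with a stated time of 60 min, tested at 1 uM (a lower number here means less inhibition, a higher number more inhibition at the concentration tested (going by the name of the read-out)), compound 1 gives 46%. Compound 2 `Cc1cc(C)cc(S(=O)(=O)c2cnc3ccc(F)cc3c2N2CCC(C)CC2)c1` carries a fluoro on the fused system and a differently substituted arylsulfonyl group. In this assay compound 2 gives 83%. Compound 2 stands highest of the two numbers; its nearest neighbour is compound 1, whose number is lower by an amount beyond the scatter. Going by the values given here, because the two differ in more than one place, no single step between them is set out.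

Compound 3 `Cc1cc(C)cc(S(=O)(=O)c2cnc3ccc(Cl)cc3c2N2CCC(C)CC2)c1` awaits measurement. It differs from compound 2 in one place: chloro in place of fluoro on an aromatic carbon. Compound 1 also bears chloro there, but its other ring differs as well, so it cannot isolate this swap. He expects the step from compound 2 to compound 3 to be small, a slight fall within the scatter, as a number 5 percentage points lower from compound 2 to compound 3 (within the scatter). Compound 3 is therefore estimated at 78%, within 60% to 92%.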

Compound 3, a percentage reported as inhibition, at one concentration (the size of the read-out at that concentration, not a potency): 49%
Compound 3: the middle estimate sits 29 percentage points above what was measured, outside the stated range (below it).
By their numbers in this assay, from the lowest: compounds 1 and 3 (each within the scatter of the next); then compound 2.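

In this assay, going by these compounds alone, the single swap of chloro in place of fluoro on this aromatic carbon, part of the fused system of two rings, gives a number 34 percentage points lower from compound 2 to compound 3 (beyond the scatter), so for this pair the identity of the halogen alone separates the two results by more than the scatter, something the first two compounds could not show since they also differ in their arylsulfonyl groups. With chloro held on this carbon, 3,5-dimethylphenyl in place of 3-chloro-4-methoxyphenyl on the sulfonyl sulfur gives a number 3 percentage points higher from compound 1 to compound 3 (within the scatter), which leaves compound 1 and compound 3 within the scatter of each other, so this pair shows no measurable effect of that exchange. Nothing available here accounts for the size of the halogen step. Within the data shown here, whether the exchange of arylsulfonyl groups would stay as small with fluoro on this carbon remains open, as the one pair that tests it carries chloro. Also open, on these data alone, is how a bromo, a nitrile or a trifluoromethyl on this same carbon would compare with fluoro and chloro.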